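Isopropoxy for cyano at the assay limit

The source may report more compounds than this note shows. Statements on the series, on what has been measured and on what is new or still open speak of the compounds shown alone.

In a functional assay on DLD-1 cells (Homo sapiens) for cytotoxicity, with a stated time of 48 h (a higher number here means a weaker inhibitor, a lower number a stronger inhibitor), compound 3 `C[S+]([O-])/C=C/c1cc(=O)c2cc(C#N)ccc2o1` gives no number, only a limit of > 10000 nM. Compound 1 `CC(=O)Oc1ccc2oc(/C=C/[S+](C)[O-])cc(=O)c2c1` also gives only a limit, > 10000 nM. Going by the values given here, compound 2 `C[S+]([O-])/C=C/c1cc(=O)c2cc(Cl)ccc2o1` gives 6500 nM, the one true number so far. The next change leads to compound 4 `CC(C)Oc1ccc2oc(/C=C/[S+](C)[O-])cc(=O)c2c1`: isopropoxy in place of cyano on an aromatic carbon. Among the compounds with values here, the steps that bear on it are an at least 1.5-fold higher number from compound 2 to compound 3 (0.18 log units; that floor lies within the scatter) and an at least 1.5-fold lower number from compound 1 to compound 2 (0.18 log units; that floor lies within the scatter), while a step that the two limits leave unreadable from compound 1 to compound 3 offers no size at all. None of these shows a change beyond the scatter, so no step beyond the scatter is expected in this assay, in either direction. The expected change is an at least 1.1-fold lower number from compound 3 to compound 4 (0.04 log units; that floor lies within the scatter). For compound 4 the estimated value is 9000 nM, within an expected range of 4000 nM to 20000 nM.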

Compound 4, half-maximal inhibitory concentration: 8000 nM
Compound 4: middle estimate off by 1.1-fold (0.05 log units), on the high side; measured number inside the range.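

In this assay, isopropoxy gives a second true number on this aromatic carbon, and it cannot be told apart from chloro: a 1.2-fold higher number from compound 2 to compound 4 (0.09 log units; within the scatter). Against the two compounds that carry only a limit, an at least 1.2-fold lower number from compound 3 to compound 4 (0.09 log units; that floor lies within the scatter) and an at least 1.2-fold lower number from compound 1 to compound 4 (0.09 log units; that floor lies within the scatter) are floors, and neither clears the scatter. These two steps stay floors because of the assay limit: the limit of > 10000 nM in this assay, at which 2 of the 4 values shown sit.

On these data alone, whether any group at this position can move the number beyond the scatter remains open. An amine, a carboxylic acid or a longer alkoxy chain on the same carbon would test that.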